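A Hydroxyl for a Trifluoromethoxy on a Second Core

The source may report more compounds than this note shows. Statements on the series, on what has been measured and on what is new or still open speak of the compounds shown alone.

Three measured compounds and one awaiting measurement make up this set. Compound 1 `Oc1cccc2[nH]c(-c3ccc(-c4ccc(-c5ccc(OC(F)(F)F)cc5)cc4)cc3)nc12` is the reference; in a functional assay on KB cells (Homo sapiens) for inhibition, read by sulforhodamine B assay (a higher number here means a weaker inhibitor of growth, a lower number a stronger inhibitor of growth), compound 1 gives 3310 nM. Compound 2 `Oc1ccc(-c2ccc(-c3ccc(-c4nc5c(O)cccc5[nH]4)cc3)cc2)cc1` differs from it by hydrogen in place of trifluoromethyl on an oxygen on an aromatic ring. In this assay compound 2 gives 3190 nM, and the step of a 1.0-fold lower number from compound 1 to compound 2 (0.02 log units; within the scatter). Compound 3 `Cc1ccc2[nH]c(-c3ccc(-c4ccc(-c5ccc(OC(F)(F)F)cc5)cc4)cc3)nc2c1` keeps the trifluoromethoxy end but changes the core: it differs from compound 1 by 5-methyl-1H-benzimidazol-2-yl in place of 4-hydroxy-1H-benzimidazol-2-yl on an aromatic carbon. In this assay compound 3 gives 41200 nM, the step being a 12-fold higher number from compound 1 to compound 3 (1.10 log units; beyond the scatter), which leaves compound 3 with the highest number of the three.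

Compound 4 `Cc1ccc2[nH]c(-c3ccc(-c4ccc(-c5ccc(O)cc5)cc4)cc3)nc2c1` has not been measured. It differs from compound 3 by hydrogen in place of trifluoromethyl on an oxygen on an aromatic ring. This is the same change that separates compound 1 from compound 2, and the description of the place around it reads the same word for word in both pairs, so it is the same change carried onto the core of compound 3; among these compounds it occurs twice. For the measured compounds named here, its one measured instance lies within the scatter, so compound 4 is expected to sit close to compound 3 in this assay, with an expected step of a 1.0-fold lower number from compound 3 to compound 4 (0.01 log units; within the scatter), a view that rests on compound 1 and compound 2 and the step of a 1.0-fold lower number from compound 1 to compound 2 (0.02 log units; within the scatter). Going by the values given here, the cores differ, and that pair is the only guide here. In this assay compound 4 is expected to give 40000 nM, estimated to lie between 15000 nM and 110000 nM.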

Compound 4, concentration for 50% growth inhibition: 21200 nM
Compound 4: the middle estimate sits 1.9-fold (0.28 log units) above what was measured, and the stated range covers the measured number.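

In this assay, hydrogen in place of trifluoromethyl on the oxygen, now on the core of compound 3, gives a 1.9-fold lower number from compound 3 to compound 4 (0.29 log units; within the scatter), so this pair, like the pair on the core of compound 1, stays within the usual scatter. Set side by side, the two instances of the change do not differ by more than two such steps can be expected to differ: the same change on two cores in this assay, a 1.0-fold lower number (0.02 log units; within the scatter) from compound 1 to compound 2 and a 1.9-fold lower number (0.29 log units; within the scatter) from compound 3 to compound 4, 1.9-fold (0.27 log units) apart, within the scatter of two such steps This shows that, on these two cores and in this one assay, the swap of trifluoromethoxy for hydroxy carried across with no difference that can be told from scatter, but it does not show that the same would hold on any further core, nor can it exclude a small dependence on the core that lies inside the scatter of the two steps.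

The compounds shown leave open whether the same holds for other groups at this end of the molecule, such as an amine or a carboxylic acid in place of the hydroxy on the aromatic ring. They also leave open whether the change would carry onto a core with a methoxy or a chlorine in place of the methyl of compound 3.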